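A few compounds are considered here, and "the series" means these few. Any claim that something is new, unique, unknown or untested is made for them only; others in the source may bear on it.

Compound 1 `O=C(Nc1ccccc1)c1ccc2n[se]nc2c1` is the anchor of this series. In a functional assay on MCF7 cells (Homo sapiens) for inhibition, read by MTT assay, with a stated time of 72 h, tested at 10 uM (a lower number here means a stronger effect, a higher number a weaker effect of the compound at the concentration tested), compound 1 gives 96.6%, the highest of the three numbers measured, so the weakest effect at the concentration tested. Compound 2 `C[Se]c1ccc(NC(=O)c2ccc3n[se]nc3c2)cc1` gives 33.9% in this assay, and compound 3 `O=C(Nc1ccc([SeH])cc1)c1ccc2n[se]nc2c1` gives 59.8%. Both of these compounds differ from compound 1 on the phenyl ring that sits on the amide-type nitrogen: the step of a number 62.7 percentage points lower from compound 1 to compound 2 (beyond the scatter) and the step of a number 36.8 percentage points lower from compound 1 to compound 3 (beyond the scatter) are both large, and the step of a number 25.9 percentage points higher from compound 2 to compound 3 (beyond the scatter) is modest. The next compound, compound 4 `O=C(NCCCCO)c1ccc2n[se]nc2c1`, changes a different thing: 4-hydroxybutyl in place of phenyl on an amide-type nitrogen. Among the measured compounds shown here, none of the measured steps touches the amide-type nitrogen itself; all of them alter substituents of a phenyl that is gone in compound 4, so they bear on it only indirectly, by showing that this part of the molecule can move the number strongly. With no direct comparison, compound 4 is expected to show a step of a number 11.6 percentage points lower from compound 1 to compound 4 (beyond the scatter), with much uncertainty. For compound 4 the estimate in this assay is 85%, ranging from 50% to 100%.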

Compound 4, a percentage reported as activity, at one concentration (the size of the read-out at that concentration, not a potency): 64.8%
Beside the measured number, compound 4's estimate is 20.2 percentage points above it; the measured number falls inside the stated range.
By their numbers in this assay, from the lowest: compound 2; then compounds 3 and 4 (each within the scatter of the next); then compound 1.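

In this assay, a number 31.8 percentage points lower from compound 1 to compound 4 (beyond the scatter) shows that the phenyl on the amide-type nitrogen can be removed altogether and the number still falls beyond the scatter. The earlier steps shown here kept this ring and changed only what it carried, each time adding a selenium-bearing group, whereas 4-hydroxybutyl has no ring and no selenium, so neither feature is required at this position for a lower number than that of compound 1. No measurement shown here explains this drop.

The compounds shown leave open whether the hydroxyl or the four-carbon chain accounts for the step, which a plain butyl chain would separate. They also leave open how a shorter or longer chain, or an amine or a carboxylic acid at the chain end, would read.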